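Chloro for Methyl on the Urea Core: an Estimate

A few compounds are considered here, and "the series" means these few. Any claim that something is new, unique, unknown or untested is made for them only; others in the source may bear on it.

In an ADME assay on the whole organism with Oryza sativa as the target, tested at 0.1 uM (on this read-out lower numbers stand for a stronger effect and higher numbers for a weaker effect at the one concentration tested), compound 1 `Cc1ccccc1NC(=O)N[C@H](C)c1ccccc1` gives 100%. Its mirror-image partner, compound 2 `Cc1ccccc1NC(=O)N[C@@H](C)c1ccccc1`, gives 100% in this assay, and compound 3 `CCOC(=O)c1cccc(NC(=O)N[C@@H](C)c2ccccc2)c1`, which carries an ethyl ester on the other ring, gives 100% in this assay. Compound 1 thus stands level with compounds 2 and 3 at the digits shown. Within the data shown here, the single measured step, no change at the digits printed from compound 1 to compound 2 (within the scatter), rests on the fact that compounds 1 and 2 differ only in the configuration as drawn and shows that swapping the drawn configuration changes nothing within the scatter.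

Compound 4 `C[C@@H](NC(=O)Nc1ccccc1Cl)c1ccccc1` differs from compound 1 in one place: chloro in place of methyl on an aromatic carbon. Among the measured compounds shown here, no measured step here exchanges one substituent for another on that ring, so the configuration step cannot be carried over directly; it only shows that the shared core of compound 1 sits at the weak end of this assay in every form measured. He therefore expects no step beyond the scatter for no change at the digits printed from compound 1 to compound 4 (within the scatter). Compound 4 is estimated at 100% in this assay, within 88% to 110%.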

Compound 4, a percentage reported as activity, at one concentration (the size of the read-out at that concentration, not a potency): 101%
Estimate against measurement, compound 4: 1 percentage points below; measured number inside the range.
By their numbers in this assay, from the lowest: compounds 1, 2, 3 and 4 (each within the scatter of the next).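

In this assay, chloro in place of methyl gives a number 1 percentage points higher from compound 1 to compound 4 (within the scatter), and this is the first step shown that exchanges one substituent for another rather than the configuration as drawn. It shows that at this place, on an aromatic carbon of a six-membered aromatic ring of carbon only and ortho to a large group, this exchange leaves the read-out within the scatter at the one concentration tested. Nothing given here bears on why the read-out holds through this exchange.

Going by these compounds, what an amine, a carboxylic acid or a longer chain at this place would do remains open. Also open, on these data alone, is whether chloro and methyl would part at any other concentration, since the read-out here comes from a single one.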